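The source may report more compounds than this note shows. Statements on the series, on what has been measured and on what is new or still open speak of the compounds shown alone.

Measured in a functional assay on HeLa cells (Homo sapiens) for cytotoxicity, read by cell counting, with a stated time of 4 days; a lower number here means a stronger inhibitor, a higher number a weaker inhibitor:
- compound 1, `C=C(Br)C(=O)Nc1ccc(/C=C2\SC(=O)N(Cc3cccc(F)c3)C2=O)cc1`: 5900 nM
- compound 2, `C=C(Br)C(=O)Nc1ccc(/C=C2\SC(=O)N(Cc3cccc(Cl)c3)C2=O)cc1`: 8900 nM
- compound 3, `C=C(Br)C(=O)Nc1ccc(/C=C2\SC(=O)N(CC)C2=O)cc1`: 1400 nM

Compound 3 has the lowest number of the three in this assay; its nearest neighbour is compound 1, and compound 2 stands furthest from it. The step of a 4.2-fold lower number from compound 1 to compound 3 (0.62 log units; beyond the scatter) and the step of a 6.4-fold lower number from compound 2 to compound 3 (0.80 log units; beyond the scatter) both run from a substituted benzyl group toward the small ethyl group, and both are beyond the scatter, while the step of a 1.5-fold higher number from compound 1 to compound 2 (0.18 log units; within the scatter) between the two benzyl compounds is within it. Compound 4, `C=C(Br)C(=O)Nc1ccc(/C=C2\SC(=O)N(Cc3ccc(C(F)(F)F)cc3)C2=O)cc1`, goes back the other way: 4-(trifluoromethyl)phenyl in place of methyl on a saturated chain carbon bound to an amide-type nitrogen in a ring. Since the two measured steps in the reverse direction were both modest in size, the expectation for compound 4 in this assay is a step of similar size upward, that is a weaker inhibitor, a 5.7-fold higher number from compound 3 to compound 4 (0.76 log units; beyond the scatter). The expected value for compound 4 is therefore 8000 nM, with a range from 3000 nM to 25000 nM.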

Compound 4, half-maximal inhibitory concentration: 13000 nM
For compound 4 the middle estimate is 1.6-fold (0.21 log units) below the measured one; low and high end bracket the measured number.
By their numbers in this assay, from the lowest: compound 3; then compounds 1, 2 and 4 (each within the scatter of the next, the first and the last beyond it).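

In this assay, a 9.3-fold higher number from compound 3 to compound 4 (0.97 log units; beyond the scatter) shows that a third aromatic group at this place, 4-(trifluoromethyl)phenyl, also gives a higher number than the small ethyl group, so this rise is not tied to a fluoro or chloro substituent. Among the aromatic groups, the comparison with 3-chlorophenyl, a 1.5-fold higher number from compound 2 to compound 4 (0.16 log units; within the scatter), stays within the scatter, while the comparison with 3-fluorophenyl, a 2.2-fold higher number from compound 1 to compound 4 (0.34 log units; beyond the scatter), lies just beyond it. Nothing available explains these differences.

On these data alone, what a plain benzyl group, a propyl or butyl chain, or a chain ending in an amine or a carboxylic acid would give at this place remains open, so it cannot be told whether the aromatic ring itself goes with the higher numbers. As far as these compounds go, all four compounds also share one core and one assay, so whether this order holds elsewhere is unknown.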